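This account rests on a few compounds, and the source may have more. Where it says the series, first, only, none or still open, it means among the compounds named here.

Measured compounds:
- compound 1 `CC[C@H](C)C(N)c1cc(C(F)(F)F)ccc1N1CCN(C(=O)CCc2ccc(Cl)cc2Cl)CC1`; in an assay on HEK293 cells for displacement of a labelled ligand from Melanocortin receptor 4 (Homo sapiens) (a higher number here means a weaker inhibitor, a lower number a stronger inhibitor), compound 1 gives 75 nM
- compound 2 `CCC(C)C(N)c1cc(C(F)(F)F)ccc1N1CCN(C(=O)CCc2ccc(Cl)cc2Cl)CC1`; compound 2 gives 160 nM
- compound 3 `COc1ccc(CCC(=O)N2CCN(c3ccc(C(F)(F)F)cc3[C@@H](N)CC(C)C)CC2)cc1`; compound 3 gives 350 nM

Compound 3 has the highest number of the three, so it is the weakest binder among them, with compound 2 nearest and compound 1 furthest below it. Going by the values given here, the only step between compounds that differ in one place is a 2.1-fold higher number from compound 1 to compound 2 (0.33 log units; beyond the scatter), which rests on (the fact that one of compounds 1 and 2 is drawn with a defined configuration and the other without, at the place where they differ); it says nothing about the ring at the end of the chain.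

Compound 4 `CC(C)C[C@H](N)c1cc(C(F)(F)F)ccc1N1CCN(C(=O)CCc2cccs2)CC1` differs from compound 3 by thiophen-2-yl in place of 4-methoxyphenyl on a saturated chain carbon, two bonds along the chain from a carbonyl carbon. Among the compounds with values here, no measured step changes the ring at this place: compounds 1 and 2 carry yet another ring there, but they also differ from compound 3 elsewhere, so their lower values cannot be read as a step for this change alone. With no guidance, the expected step is a small one, and the estimated change is a 1.4-fold higher number from compound 3 to compound 4 (0.15 log units; within the scatter). Compound 4 is expected to give about 500 nM, within the range 150 nM to 1600 nM.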

Compound 4, inhibition constant: 4600 nM
Beside the measured number, compound 4's estimate is 9.2-fold (0.96 log units) below it; the measured number lies above the stated range.
By their numbers in this assay, from the lowest: compound 1; then compound 2; then compound 3; then compound 4.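

The ring at the end of the chain matters a great deal in this assay: thiophen-2-yl in place of 4-methoxyphenyl gives a 13-fold higher number from compound 3 to compound 4 (1.12 log units; beyond the scatter). Going by these compounds alone, no earlier step touched this place, so this is the first direct sign that the choice of ring here can change the measured number strongly. The swap changes several things at once, as a six-membered ring becomes a five-membered one, the oxygen leaves and a sulfur enters, and nothing available explains the loss.

Still open, going by these compounds, is whether the loss follows from removing the methoxy group or from replacing the six-membered ring with thiophene; a plain phenyl ring at this place would help to separate the two. The ring carried by compound 1 and compound 2 cannot settle this, as those compounds also differ from compound 3 elsewhere.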